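The compounds below may be only part of what the source reports. "The series", "measured", "known", "first", "only" and "open" are said of these compounds alone.

Three compounds built on one shared core have numbers in a functional assay on A549 cells (Homo sapiens) for antiproliferative activity, read by sulforhodamine B assay, with a stated time of 3 days; a higher number here means a weaker inhibitor of growth, a lower number a stronger inhibitor of growth. There, compound 3 `O=C(Nc1cccc(Nc2ncc(F)c(Nc3ccc(F)cc3)n2)c1)c1ccncc1` gives 1650 nM and compound 2 `CN1CCC(C(=O)Nc2cccc(Nc3ncc(F)c(Nc4ccc(F)cc4)n3)c2)CC1` gives 1330 nM, a pair that cannot be told apart: a 1.2-fold higher number from compound 2 to compound 3 (0.09 log units; within the scatter). Compound 1 `O=C(Nc1ccccn1)c1cccc(Nc2ncc(F)c(Nc3ccc(F)cc3)n2)c1` gives 15300 nM, so compound 3 stands far below compound 1 and level with compound 2.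

Compound 4 `Cn1ccnc1NC(=O)c1cccc(Nc2ncc(F)c(Nc3ccc(F)cc3)n2)c1` differs from compound 3 in one place: (1-methyl-1H-imidazol-2-yl)carbamoyl in place of ((pyridin-4-yl)carbonyl)amino on an aromatic carbon. Put simply, (1-methyl-1H-imidazol-2-yl)carbamoyl comes in place of ((pyridin-4-yl)carbonyl)amino on an aromatic carbon. Compound 1 also carries a carbamoyl group, so the closest guides are the steps away from it: a 9.3-fold lower number from compound 1 to compound 3 (0.97 log units; beyond the scatter) and a 12-fold lower number from compound 1 to compound 2 (1.06 log units; beyond the scatter). Both are large, and reversing that kind of change points to a higher number. Among the compounds with values here, no tested compound carries the 1-methyl-1H-imidazol-2-yl group, so the size is uncertain, and only part of that rise is assumed. The expected change in this assay is a 3.6-fold higher number from compound 3 to compound 4 (0.56 log units; beyond the scatter). Compound 4 is estimated at 6000 nM, with an expected range of 1800 nM to 20000 nM.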

Compound 4, concentration for 50% growth inhibition: 10100 nM
For compound 4 the middle estimate is 1.7-fold (0.23 log units) below the measured one; the measured number falls inside the stated range.
By their numbers in this assay, from the lowest: compounds 2 and 3 (each within the scatter of the next); then compounds 4 and 1 (each within the scatter of the next).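

In this assay, the carbamoyl link on this aromatic carbon now goes with high numbers for a second ring, with a 6.1-fold higher number from compound 3 to compound 4 (0.79 log units; beyond the scatter) and a 7.6-fold higher number from compound 2 to compound 4 (0.88 log units; beyond the scatter) as the steps away from the two compounds carrying the reversed carbonylamino link. Exchanging the ring on the amide-type nitrogen gives no readable change, with a 1.5-fold lower number from compound 1 to compound 4 (0.18 log units; within the scatter) as the step, so among these four compounds the two carbamoyl compounds sit together with higher numbers, and none goes against that split. No measured evidence accompanies these results to explain the split. Still open, as far as these compounds go, is whether the link or its ring drives the difference, as a carbamoyl carrying 1-methylpiperidin-4-yl or a carbonylamino carrying 1-methyl-1H-imidazol-2-yl would show. From the compounds shown here alone, how an amine or a carboxylic acid on this aromatic carbon would compare also remains open.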